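The compounds below may be only part of what the source reports. "The series", "measured", "known", "first", "only" and "open" are said of these compounds alone.

In a functional assay (on this read-out lower numbers stand for stronger inhibition and higher numbers for weaker inhibition), compound 3 `CC(C)=CCOc1ccc2c(c1)OC(c1ccc(Br)cc1)CC2=O` gives 8120 nM. This lies within the scatter of the other two measured compounds: compound 1 `CC(C)=CCOc1ccc2c(c1)OC(c1ccccc1)CC2=O` gives 6070 nM and compound 2 `CC(C)=CCOc1ccc2c(c1)OC(c1ccccc1F)CC2=O` gives 6360 nM. The next compound, compound 4 `CC(C)=CCOc1ccc2c(c1)OC(c1ccc(C)cc1C)CC2=O`, has 2,4-dimethylphenyl in place of 4-bromophenyl on a saturated ring carbon. Three measured steps change the same phenyl group: a 1.0-fold higher number from compound 1 to compound 2 (0.02 log units; within the scatter), a 1.3-fold higher number from compound 1 to compound 3 (0.13 log units; within the scatter) and a 1.3-fold higher number from compound 2 to compound 3 (0.11 log units; within the scatter). All three stay within the scatter, so no step beyond the scatter is expected in this assay. Within the data shown here, no measured compound carries a methyl group on that phenyl, so this expectation rests on thin evidence. The expected change is a 1.2-fold lower number from compound 3 to compound 4 (0.06 log units; within the scatter). Compound 4 is estimated at 7000 nM, with an expected range from 3500 nM to 14000 nM.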

Compound 4, half-maximal inhibitory concentration: 8260 nM
For compound 4 the middle estimate is 1.2-fold (0.07 log units) below the measured one; measured number inside the range.
By their numbers in this assay, from the lowest: compounds 1, 2, 3 and 4 (each within the scatter of the next).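

Replacing the other phenyl groups with 2,4-dimethylphenyl gives a 1.0-fold higher number from compound 3 to compound 4 (0.01 log units; within the scatter), a 1.3-fold higher number from compound 2 to compound 4 (0.11 log units; within the scatter) and a 1.4-fold higher number from compound 1 to compound 4 (0.13 log units; within the scatter). The phenyl on this saturated ring carbon therefore carries two methyl groups, as well as a fluoro or a bromo, with no step beyond the scatter. Nothing available explains this flat result. Still open, going by these compounds, is whether an amine or a carboxylic acid on this phenyl, or a longer chain in its place, would give a step beyond the scatter.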